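The source may report more compounds than this note shows. Statements on the series, on what has been measured and on what is new or still open speak of the compounds shown alone.

Working notes on the amide series built on the shared core of compound 1 `CCN(CC)CCNc1cc(C)c2cc(NC(=O)c3ccc(Cl)c(Cl)c3)ccc2n1`, compound 2 `CCN1CCN(c2cc(C)c3cc(NC(=O)c4ccc(OC)cc4)ccc3n2)CC1` and compound 3 `CNc1cc(C)c2cc(NC(=O)c3ccc(Cl)c(Cl)c3)ccc2n1`, all measured in a functional assay on SK-BR-3 cells (Homo sapiens) for antiproliferative activity, read by MTT assay, with a stated time of 72 h; a higher number here means a weaker inhibitor, a lower number a stronger inhibitor. Among the compounds with values here, compound 1 gives 3710 nM, compound 3 gives 6350 nM, and the single one-place step recorded, a 1.7-fold higher number from compound 1 to compound 3 (0.23 log units; within the scatter), changes only the amine side chain. Within the data shown here, compound 2 gives 9000 nM, the highest number of the three; its gap to compound 3 is within the scatter, its gap to compound 1 is beyond it, and since compound 2 differs from both in two places no single step is recorded for either pair.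

Compound 4 `CCN1CCN(c2cc(C)c3cc(NC(=O)c4cc5ccccc5[nH]4)ccc3n2)CC1` differs from compound 2 by 1H-indol-2-yl in place of 4-methoxyphenyl on a carbonyl carbon. Among the measured compounds shown here, no measured step touches the group on the carbonyl carbon, so none bears on this change; the one step available concerns a different part of the molecule and gives no guidance. In this assay the expected step is a 1.3-fold lower number from compound 2 to compound 4 (0.11 log units; within the scatter), that is nothing beyond the scatter. Compound 4 is therefore estimated at 7000 nM, with a range of 2500 nM to 20000 nM.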

Compound 4, half-maximal inhibitory concentration: 2550 nM
Compound 4: middle estimate off by 2.7-fold (0.44 log units), on the high side; the range from low to high includes it.
By their numbers in this assay, from the lowest: compounds 4, 1, 3 and 2 (each within the scatter of the next, the first and the last beyond it).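

In this assay, within the data shown here, the group on the carbonyl carbon is the only place so far where a one-place change moves the number beyond the scatter (a 3.5-fold lower number from compound 2 to compound 4 (0.55 log units; beyond the scatter)), whereas the step on the amine side chain stays within it (a 1.7-fold higher number from compound 1 to compound 3 (0.23 log units; within the scatter)). This one step exchanges several features at once: 1H-indol-2-yl brings a five-membered aromatic ring with a hetero atom and a hydrogen-bond donor, while 4-methoxyphenyl takes away a hydrogen-bond acceptor, and the data cannot assign the lower number to any one of these. Nothing available explains the step.

Going by these compounds, it remains open whether the hydrogen on the indole nitrogen matters, which a 1-methyl-1H-indol-2-yl group on the same carbonyl carbon would address. On these data alone, it also remains open whether 1H-indol-2-yl gives a similar step when paired with the amine side chain of compound 1.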